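From acetyl to ethoxycarbonyl on compound 3

This account rests on a few compounds, and the source may have more. Where it says the series, first, only, none or still open, it means among the compounds named here.

Compound 1 `Cc1ccc(S(=O)(=O)NC(C)C2=CC(=O)c3c(O)ccc(O)c3C2=O)cc1` gives 5340 nM
Compound 2 `CC(NS(=O)(=O)c1ccc(Br)cc1)C1=CC(=O)c2c(O)ccc(O)c2C1=O` gives 5210 nM
Compound 3 `CC(=O)c1ccc(S(=O)(=O)NC(C)C2=CC(=O)c3c(O)ccc(O)c3C2=O)cc1` gives 5760 nM

These three values come from a functional assay on HeLa cells (Homo sapiens) for cytotoxicity, read by sulforhodamine B assay (on this read-out higher numbers stand for weaker inhibition and lower numbers for stronger inhibition), and they cannot be told apart. Compound 3 stands level with the other two: one measured step is a 1.1-fold higher number from compound 1 to compound 3 (0.03 log units; within the scatter), and the other is a 1.1-fold higher number from compound 2 to compound 3 (0.04 log units; within the scatter).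

The account now turns to compound 4 `CCOC(=O)c1ccc(S(=O)(=O)NC(C)C2=CC(=O)c3c(O)ccc(O)c3C2=O)cc1`, which keeps the shared core and alters only the acetyl group of compound 3. The change is ethoxy in place of methyl on a carbonyl carbon, so acetyl becomes ethoxycarbonyl.

For the measured compounds named here, no measured step makes this exact exchange. The closest evidence comes from the swaps of groups on an aromatic carbon. Besides the two steps above, there is a 1.0-fold lower number from compound 1 to compound 2 (0.01 log units; within the scatter). None of the three steps leaves the scatter, and none goes against that picture, although three compounds are a narrow base. On that evidence, no step beyond the scatter is expected in this assay, and no direction is favoured. The estimated step is a 1.0-fold lower number from compound 3 to compound 4 (0.02 log units; within the scatter).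

For compound 4 the estimated value is 5500 nM, with an expected range from 3300 nM to 9000 nM.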

Compound 4, half-maximal inhibitory concentration: 2260 nM
Estimate against measurement, compound 4: 2.4-fold (0.39 log units) above; the whole stated range lies above it.
By their numbers in this assay, from the lowest: compound 4; then compounds 2, 1 and 3 (each within the scatter of the next).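

In this assay, for the compounds shown here, methyl, bromo and acetyl on this aromatic carbon could not be told apart, and ethoxycarbonyl is the first group here to move the number beyond the scatter (a 2.5-fold lower number from compound 3 to compound 4 (0.41 log units; beyond the scatter)), with the same direction against the other two compounds (a 2.3-fold lower number from compound 2 to compound 4 (0.36 log units; beyond the scatter); a 2.4-fold lower number from compound 1 to compound 4 (0.37 log units; beyond the scatter)). The exchange of methyl for ethoxy on the carbonyl carbon therefore shows that this position is not indifferent to what it carries, even though each of these steps is modest and acetyl and ethoxycarbonyl both keep a carbonyl on the aromatic carbon. Nothing available bears on why the number moved.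

The compounds shown leave open whether the step follows the added oxygen or the ethyl chain, which a methoxycarbonyl group, a carboxylic acid or a longer propoxycarbonyl chain on the same aromatic carbon could begin to separate. They also leave open whether an amide in that place would go with compound 4 or with the three compounds that stand level.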